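Methyl to Chloro on a Shared Core: What to Expect

The source may hold more compounds than are shown below. What is called first, only, known or untested is meant among the compounds shown, and "the series" means these compounds.

Of the compounds shown here, two have been tested so far in a functional assay on MCF7 cells (Homo sapiens) for cytotoxicity, read by MTT assay, with a stated time of 72 h; a higher number here means a weaker inhibitor, a lower number a stronger inhibitor. Compound 1, `O=C1CS/C(=N\c2csc(-c3ccc(Cl)cc3)c2)N1`, gives > 50000 nM, which is a limit of the assay rather than a measured number. Compound 2, `COc1cccc(N2C(=O)CS/C2=N\c2csc(-c3ccc(C)cc3)c2)c1`, gives > 50000 nM, again only a limit. Within the data shown here, compound 2 therefore stands at the edge of what this assay can report, and the one other value shown sits at the same place: the limit of > 50000 nM in this assay, at which 2 of the 2 values shown sit.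

Compound 3, `COc1cccc(N2C(=O)CS/C2=N\c2csc(-c3ccc(Cl)cc3)c2)c1`, differs from compound 2 in one place: chloro in place of methyl on an aromatic carbon. Among the measured compounds shown here, no step between two measured compounds is available to gauge this swap; compound 1 carries the same 4-chlorophenyl group and also sits at the limit. The expected step from compound 2 to compound 3 in this assay is therefore none beyond the usual scatter, a step that the limit leaves unreadable from compound 2 to compound 3. Compound 3 is expected to give 60000 nM, in the range 20000 nM to 200000 nM, most likely reported again only as a limit.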

Compound 3, half-maximal inhibitory concentration: > 50000 nM
Compound 3: no number, only a limit; the forecaster's own chance of this, stated with the estimate: 85%; the middle value is on the limit's open side.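

Compound 3 gives > 50000 nM, again a limit and not a number. No step from compound 1 or compound 2 to compound 3 can be read in this assay: the limit of > 50000 nM in this assay, at which 3 of the 3 values shown sit.

The compounds shown leave open whether any change to the shared core would give a readable value in this assay.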